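Swapping a ring for a chain at the imidazole nitrogen

The compounds below may be only part of what the source reports. "The series", "measured", "known", "first", "only" and "open" are said of these compounds alone.

Measured compounds in a functional assay on HCC827 cells (Homo sapiens) for antiproliferative activity, read by MTT assay, with a stated time of 72 h; on this read-out lower numbers stand for stronger inhibition and higher numbers for weaker inhibition:
compound 1 `CN1CCN(c2ccc(Nc3ncc4nc(Nc5ccc(F)cc5)n([C@@H]5CCN(C(=O)CO)C5)c4n3)cc2)CC1`: 350 nM
compound 2 `CN1CCN(c2ccc(Nc3ncc4nc(Nc5ccc(F)cc5)n([C@H]5CCCNC5)c4n3)cc2)CC1`: 38 nM
compound 3 `CN1CCN(c2ccc(Nc3ncc4nc(Nc5ccc(F)cc5)n([C@H]5CCCN(C(=O)CO)C5)c4n3)cc2)CC1`: 1.8 nM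

Compound 1 gives the highest of the three numbers; compound 2 lies nearest to it and compound 3 furthest away. Compound 4 `CN1CCN(c2ccc(Nc3ncc4nc(Nc5ccc(F)cc5)n(CCNS(=O)(=O)C5CC5)c4n3)cc2)CC1` differs from compound 1 in one place: 2-((cyclopropylsulfonyl)amino)ethyl in place of 1-((hydroxymethyl)carbonyl)pyrrolidin-3-yl on an aromatic nitrogen. Both measured steps that start from compound 1 also alter the group on that same aromatic nitrogen: a 9.2-fold lower number from compound 1 to compound 2 (0.96 log units; beyond the scatter) and a 190-fold lower number from compound 1 to compound 3 (2.29 log units; beyond the scatter). Both lowered the number, though neither replaces the ring with an open chain, so they guide only loosely. Changes at this position have so far moved the read-out substantially, and a lower number than compound 1 is expected, of size a 3.5-fold lower number from compound 1 to compound 4 (0.54 log units; beyond the scatter). Compound 4 is estimated at 100 nM, between 15 nM and 700 nM.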

Compound 4, half-maximal inhibitory concentration: 50 nM
Compound 4: middle estimate off by 2.0-fold (0.30 log units), on the high side, within the range that was stated.
By their numbers in this assay, from the lowest: compound 3; then compounds 2 and 4 (each within the scatter of the next); then compound 1.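

An open chain can take the place of a ring on this aromatic nitrogen: 2-((cyclopropylsulfonyl)amino)ethyl gives a 7.0-fold lower number from compound 1 to compound 4 (0.85 log units; beyond the scatter), so a ring at this position is not required for a low number. The chain does not reach the level of the 1-((hydroxymethyl)carbonyl)piperidin-3-yl group, with a 28-fold higher number from compound 3 to compound 4 (1.44 log units; beyond the scatter). Against the plain piperidin-3-yl group, a 1.3-fold higher number from compound 2 to compound 4 (0.12 log units; within the scatter) lies within the scatter, so these two groups cannot be told apart here.

No measurement shown explains these differences. Going by these compounds, whether a longer chain, or an ethyl chain ending in a simple amine or a carboxylic acid, would come closer to compound 3 remains open.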